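The source may report more compounds than this note shows. Statements on the series, on what has been measured and on what is new or still open speak of the compounds shown alone.

Measured so far:
- compound 1 `COc1cccc(/C=C2\CCC/C(=C\c3ccc(Br)cc3)C2=O)c1OC`: 21400 nM
- compound 2 `COc1cccc(/C=C2\CCC/C(=C\c3cccc(O)c3)C2=O)c1OC`: 19300 nM

Going by the values given here, in an ADME assay on NHDF cells (Homo sapiens) for cytotoxicity, read by MTT assay, with a stated time of 72 h (on this read-out higher numbers stand for weaker inhibition and lower numbers for stronger inhibition), compound 2 gives 19300 nM and sits level with compound 1, the only other measured compound. The next compound, compound 3 `COc1cccc(/C=C2\CCC/C(=C\c3ccc(Cl)cc3Cl)C2=O)c1OC`, has not been measured. It carries 2,4-dichlorophenyl in place of 3-hydroxyphenyl on a double-bonded chain carbon bound to a double-bonded ring carbon.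

Among the compounds with values here, only one measured step bears on this change, and it altered the group at that same place: a 1.1-fold lower number from compound 1 to compound 2 (0.04 log units; within the scatter). That step stayed within the scatter, and one step is thin evidence. Even so, it gives no reason to expect a real shift in this assay. The step of a 1.0-fold lower number from compound 2 to compound 3 (0.01 log units; within the scatter) is therefore expected to stay within the scatter, with no favoured direction. For compound 3 the estimated value is 19000 nM, with an expected range from 9000 nM to 40000 nM.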

Compound 3, half-maximal inhibitory concentration: 49200 nM
Beside the measured number, compound 3's estimate is 2.6-fold (0.41 log units) below it; the measured number lies above the stated range.
By their numbers in this assay, from the lowest: compounds 2 and 1 (each within the scatter of the next); then compound 3.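

In this assay this position proves not to be indifferent to the group it carries: 2,4-dichlorophenyl raises the number modestly, both against 3-hydroxyphenyl (a 2.5-fold higher number from compound 2 to compound 3 (0.41 log units; beyond the scatter)) and against 4-bromophenyl (a 2.3-fold higher number from compound 1 to compound 3 (0.36 log units; beyond the scatter)). A higher number here means weaker inhibition, so compound 3 is the weakest of the three, while the earlier pair alone had shown no real change on swapping the group at this place. Nothing measured here accounts for this difference.

From the compounds shown here alone, whether a single chlorine, as in 4-chlorophenyl or 2-chlorophenyl, would move the number as far as the two together remains open. Also open, going by these compounds, is what a phenyl ring carrying an amine or a carboxylic acid would do at this place.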